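From 4-bromophenyl to 3-nitrophenyl: an expected flat step

The source may hold more compounds than are shown below. What is called first, only, known or untested is meant among the compounds shown, and "the series" means these compounds.

Measured so far in a functional assay on SK-N-SH cells (Homo sapiens) for cytotoxicity, read by MTT assay, with a stated time of 24 h (on this read-out lower numbers stand for stronger inhibition and higher numbers for weaker inhibition), are these compounds:
compound 1 `COc1cc(/C=C(\C#N)C(=O)N/N=C(\C)c2c(O)c3ccc(O)cc3oc2=O)ccc1O` gives 14400 nM
compound 2 `C/C(=N\NC(=O)/C(C#N)=C/c1ccc(Br)cc1)c1c(O)c2ccc(O)cc2oc1=O` gives 12100 nM

Compound 2 stands level with compound 1, as their values lie within the scatter of each other. Compound 3 `C/C(=N\NC(=O)/C(C#N)=C/c1cccc([N+](=O)[O-])c1)c1c(O)c2ccc(O)cc2oc1=O` has 3-nitrophenyl in place of 4-bromophenyl on a double-bonded chain carbon bound to a double-bonded chain carbon. Among the measured compounds shown here, only one measured step bears on this place, a 1.2-fold lower number from compound 1 to compound 2 (0.08 log units; within the scatter) and it stayed within the scatter. For the measured compounds named here, that is thin evidence, and no compound with 3-nitrophenyl has yet been measured. In this assay the expected outcome is a 1.0-fold lower number from compound 2 to compound 3 (0.00 log units; within the scatter) with no change expected beyond the scatter. Compound 3 is estimated at 12000 nM with an expected range from 5000 nM to 28000 nM in this read-out.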

Compound 3, half-maximal inhibitory concentration: 28300 nM
Compound 3: middle estimate off by 2.4-fold (0.37 log units), on the low side; the measured number lies above the stated range.
By their numbers in this assay, from the lowest: compounds 2, 1 and 3 (each within the scatter of the next, the first and the last beyond it).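

In this assay, this place on a double-bonded chain carbon bound to a double-bonded chain carbon now proves able to move the number, since 3-nitrophenyl in place of 4-bromophenyl gives the first step there beyond the scatter, though a modest one (a 2.3-fold higher number from compound 2 to compound 3 (0.37 log units; beyond the scatter)). Replacing 4-hydroxy-3-methoxyphenyl with 3-nitrophenyl stays within the scatter (a 2.0-fold higher number from compound 1 to compound 3 (0.29 log units; within the scatter)), so the shift shows only against 4-bromophenyl. Nothing given here explains this step.

As far as these compounds go, it remains open whether 4-nitrophenyl would read like 3-nitrophenyl, and whether an amine or a carboxylic acid on the phenyl ring would shift the number further.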